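The compounds below may be only part of what the source reports. "The series", "measured", "known", "first", "only" and "open" are said of these compounds alone.

Three compounds built on one shared core have been examined in an ADME assay on BJ cells (Homo sapiens) for cytotoxicity, read by luminescence, with a stated time of 72 h; on this read-out higher numbers stand for an effect only at larger amounts of compound and lower numbers for an effect already at smaller amounts. Compound 1 `CCOC(=O)c1c(-c2cccc(-c3ccccc3)c2)[nH]c2cc(OC)ccc2c1=O` carries a phenyl on an aromatic carbon of the core, while compound 2 `CCOC(=O)c1c(-c2cccc(OC)c2)[nH]c2cc(OC)ccc2c1=O` and compound 3 `CCOC(=O)c1c(-c2cccc(OC(C)C)c2)[nH]c2cc(OC)ccc2c1=O` carry a methoxy and an isopropoxy at that place. In this assay compound 1 reaches only a limit of the assay, > 21500 nM. Compound 2 likewise reaches only a limit, > 21500 nM. For compound 3 the result is again only a limit, > 21500 nM. The step that the two limits leave unreadable from compound 2 to compound 3 therefore cannot be sized, because all three values sit at the limit of > 21500 nM in this assay, at which 3 of the 3 values shown sit.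

The change from compound 2 to compound 3 is isopropyl in place of methyl on an oxygen on an aromatic ring. Compound 1 and compound 2 differ in their cores by phenyl in place of methoxy on an aromatic carbon. Among the compounds with values here, compound 4 `CCOC(=O)c1c(-c2cccc(-c3ccccc3)c2)[nH]c2cc(OC(C)C)ccc2c1=O` has not yet been measured; it differs from compound 1 by isopropyl in place of methyl on an oxygen on an aromatic ring, which is the same change as the one from compound 2 to compound 3, made at the same kind of place on the other core.

Since compound 1 gives only a limit of > 21500 nM, and the same change on the other core left compound 3 at a limit as well, the step that the limit leaves unreadable from compound 1 to compound 4 is expected to stay within the unreadable range in this assay. Compound 4 is therefore estimated at 30000 nM, most likely reported once more as a limit, between 15000 nM and 70000 nM.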

Compound 4, half-maximal effective concentration: > 21500 nM
Compound 4 was reported as a limit (the forecaster's own chance of this, stated with the estimate: 85%); the middle value does not contradict the limit.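

In this assay, within the data shown here, compound 4 gives only a limit, and no step from compound 1 to compound 4, or among compounds 1, 2 and 3, can be read, because all the values sit at the same limit: the limit of > 21500 nM in this assay, at which 4 of the 4 values shown sit. The compounds shown leave open at what amount, if any, each of the four would harm these cells, and whether the changes between them matter.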